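A few compounds are considered here, and "the series" means these few. Any claim that something is new, unique, unknown or untested is made for them only; others in the source may bear on it.

Compound 1 `N#CN/C(=N\C1CCCC1)Nc1cccnc1`: 20 mg/kg; compound 2 `CC(C)C(/N=C(\NC#N)Nc1cccnc1)C(C)C`: 5 mg/kg; compound 3 `N#CN/C(=N\Cc1ccccc1)Nc1cccnc1`: 20 mg/kg.

Of the compounds shown here, three sharing one core have been tested in a functional assay on the whole organism (blood, strain Wistar-Okamoto) with Rattus norvegicus as the target, with a stated time of 5 days; a higher number here means that more compound is needed for the effect, a lower number that less compound is needed. Compound 1 gives 20 mg/kg, which is level with compound 3 at 20 mg/kg, the two together being the highest of the three numbers; compound 2, at 5 mg/kg, gives a lower number than compound 1, beyond the scatter. Compound 4 `N#CN/C(=N\c1ccccc1)Nc1cccnc1` has not yet been measured. It differs from compound 1 in one place: phenyl in place of cyclopentyl on a double-bonded nitrogen. Going by the values given here, no measured pair shows this exact change, so its size can only be guessed. Because compound 1 already sits at 20 mg/kg, a modest move to a higher number is expected, about a 1.5-fold higher number from compound 1 to compound 4 (0.18 log units; within the scatter) in this assay. Compound 4 is therefore estimated at 30 mg/kg, within a range of 10 mg/kg to 100 mg/kg.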

Compound 4, minimum effective dose: 5 mg/kg
Beside the measured number, compound 4's estimate is 6.0-fold (0.78 log units) above it; measured number outside the range, below it.
By their numbers in this assay, from the lowest: compounds 2 and 4 (each within the scatter of the next); then compounds 1 and 3 (each within the scatter of the next).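

Phenyl in place of cyclopentyl on a double-bonded nitrogen gives a 4.0-fold lower number from compound 1 to compound 4 (0.60 log units; beyond the scatter) in this assay. Going by these compounds alone, this is the first change in a single place that can be read, and it shows that the group at this position affects the dose needed, with the aromatic ring needing less compound than the non-aromatic ring. Nothing available explains this step. Still open, from the compounds shown here alone, is how this position would respond to an amine, a carboxylic acid or a longer chain, and whether groups added to the phenyl ring would lower the number further.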